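The compounds below may be only part of what the source reports. "The series", "measured", "known", "first", "only" and "open" are said of these compounds alone.

Compound 2 `O=C(O)Cc1sc(C(c2ccc(F)cc2)c2ccc(F)cc2)nc1-c1ccnc(N2CCC2)c1` reaches 80% in an in vitro functional assay on HEK285-7 cells for antagonist activity at prostaglandin D2 receptor 2 (Homo sapiens), read by BRET and beta-arrestin recruitment (a lower number here means a smaller maximal response, a higher number a larger maximal response), and stands level with compound 1 `O=C(O)Cc1sc(C(c2ccc(F)cc2)c2ccc(F)cc2)nc1-c1ccoc1`, which reaches 80% in this assay; the step of no change at the digits printed from compound 1 to compound 2 (within the scatter) lies within the scatter. Compound 3 `CN(C)c1cc(-c2nc(C(c3ccc(F)cc3)c3ccc(F)cc3)sc2CC(=O)O)ccn1` differs from compound 2 by dimethylamino in place of azetidin-1-yl on an aromatic carbon. Among the compounds with values here, the only measured step exchanged a different part of the structure and was flat, so it offers little guidance for this smaller change. The expected step from compound 2 to compound 3 is therefore no change at the digits printed from compound 2 to compound 3 (within the scatter), none beyond the scatter. For compound 3 the estimate is 80%, with a range from 65% to 95%.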

Compound 3, largest response reached (reported as efficacy), in percent of the reference or control that the assay uses: 80%
Estimate against measurement, compound 3: no gap at the digits printed, within the range that was stated.
By their numbers in this assay, from the lowest: compounds 1, 2 and 3 (each within the scatter of the next).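

In this assay the azetidin-1-yl ring can be opened to dimethylamino at this place next to the ring nitrogen with no change at the digits printed from compound 2 to compound 3 (within the scatter) so the four-membered ring itself is not required to hold the maximal response. Exchanging furan-3-yl for 2-(dimethylamino)pyridin-4-yl likewise gives no change at the digits printed from compound 1 to compound 3 (within the scatter) and this second amine-bearing group again leaves the response level. Nothing available explains why these exchanges leave the response level. On these data alone, whether a primary amine, a morpholine ring or a methoxy group at this place would also hold the response remains open. Whether a longer chain on the nitrogen would do so is equally unknown.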